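Stilbene-type quinolines: hydroxyl position and lipophilicity

The compounds below may be only part of what the source reports. "The series", "measured", "known", "first", "only" and "open" are said of these compounds alone.

Measured compounds:
compound 1 `Clc1ccccc1/C=C/c1ccc2ccccc2n1` — 5.25
compound 2 `Clc1ccccc1/C=C/c1ccc2cccc(Cl)c2n1` — 5.85
compound 3 `Oc1ccccc1/C=C/c1ccc2c(Cl)cc(Cl)c(O)c2n1` — 5.07

Going by the values given here, in a physicochemical assay for lipophilicity, read by HPLC (on this read-out lower numbers stand for lower lipophilicity and higher numbers for higher lipophilicity), compound 1 gives 5.25 and compound 2 gives 5.85; the one step recorded, a number 0.60 log units higher from compound 1 to compound 2 (beyond the scatter), is the only change between measured compounds that differ in a single place. Compound 3 gives 5.07 and stands lowest of the three numbers, though its gap to compound 1 is within the scatter; only the gap to compound 2 is beyond it.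

Compound 4 `Oc1ccc(/C=C/c2ccc3c(Cl)cc(Cl)c(O)c3n2)cc1` is not yet measured in this assay. It differs from compound 3 in one place: 4-hydroxyphenyl in place of 2-hydroxyphenyl on a double-bonded chain carbon bound to a double-bonded chain carbon. The two have the same atoms, joined differently.

Among the compounds with values here, no measured step bears on this change: the only recorded step concerns chloro in place of hydrogen on an aromatic carbon, not a rearrangement of the hydroxyphenyl group. With nothing in the series to anchor a shift, the expectation for compound 4 is a step in this assay of about a number 0.17 log units lower from compound 3 to compound 4 (within the scatter), which is estimated to lie within the scatter. For compound 4 the estimated value in this assay is 4.9, with a range from 4.5 to 5.3.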

Compound 4, partition coefficient: 5.07
Compound 4: the middle estimate sits 0.17 log units below what was measured, within the range that was stated.
By their numbers in this assay, from the lowest: compounds 3, 4 and 1 (each within the scatter of the next); then compound 2.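

Exchanging 2-hydroxyphenyl for 4-hydroxyphenyl on a double-bonded chain carbon bound to a double-bonded chain carbon gives, in this assay, no change at the digits printed from compound 3 to compound 4 (within the scatter). Going by these compounds alone, this is the first reading of any change at this place, as the earlier step concerned only chloro in place of hydrogen on an aromatic carbon, and it shows that for this pair the read-out does not separate the two hydroxyphenyl groups, which match in every count of heavy atoms, hydrogen-bond donors and hydrogen-bond acceptors. So on this core, the exchange at this place does not register beyond the scatter, whereas the chloro step from the earlier pair did; nothing measured here offers an account of the result.

Still open, from the compounds shown here alone, is whether an amine or a carboxylic acid in place of the hydroxyl on this phenyl group would also leave the read-out where it stands. Also open, going by these compounds, is whether the same exchange of hydroxyphenyl groups would read alike on a core without the two chloro groups and the hydroxyl that compound 3 and compound 4 share.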